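This account rests on a few compounds, and the source may have more. Where it says the series, first, only, none or still open, it means among the compounds named here.

Compounds measured so far in a functional assay on Ehrlich cells (Mus musculus) for cytotoxicity, read by trypan blue exclusion, with a stated time of 2 h; on this read-out higher numbers stand for weaker inhibition and lower numbers for stronger inhibition:
compound 1, `N#CC1=C(N)N(c2ccc(S(N)(=O)=O)cc2)C2=C(C(=O)CCC2)C1c1ccc(Cl)cc1Cl`, gives 25 ug/mL
compound 2, `N#CC1=C(NC(=O)c2ccccc2)N(c2ccc(S(N)(=O)=O)cc2)C2=C(C(=O)CCC2)C1c1ccc(Cl)cc1Cl`, gives 10 ug/mL
compound 3, `N#CC1=C(NC(=O)/C=C/c2ccccc2)N(c2ccc(S(N)(=O)=O)cc2)C2=C(C(=O)CCC2)C1c1ccc(Cl)cc1Cl`, gives > 100 ug/mL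

Compound 3 stands apart from the other two in that its result is a limit of the assay and not a number: it sits at the limit of > 100 ug/mL in this assay, at which 1 of the 3 values shown sits. Compounds 1 and 2 both give numbers within this assay, and of the three steps among them only a 2.5-fold lower number from compound 1 to compound 2 (0.40 log units; beyond the scatter) lowered the number; an at least 4.0-fold higher number from compound 1 to compound 3 (0.60 log units; beyond the scatter) and an at least 10-fold higher number from compound 2 to compound 3 (1.00 log units; beyond the scatter) raised it, each to the limit.

Compound 4, `CN(C)c1ccc(/C=N/C2=C(C#N)C(c3ccc(Cl)cc3Cl)C3=C(CCCC3=O)N2c2ccc(S(N)(=O)=O)cc2)cc1`, differs from compound 3 by a group of 11 heavy atoms (9 carbon, 2 nitrogen; one six-membered aromatic ring of carbon only) in place of a group of 11 heavy atoms (9 carbon, 1 nitrogen, 1 oxygen; one six-membered aromatic ring of carbon only), on a double-bonded ring carbon. For the measured compounds named here, all three measured steps change the same amine nitrogen, and no measured step swaps an acylated nitrogen for an imine of this kind, so they bear on the new compound only loosely. They do show that changes at this position have moved the number in both directions, by modest amounts or more. Because compound 3 rests on a limit, a step downward is more probable than a step further up, and an at least 2.5-fold lower number from compound 3 to compound 4 (0.39 log units; beyond the scatter) is the expected change. Compound 4 is therefore estimated at 40 ug/mL, within the range 10 ug/mL to 120 ug/mL.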

Compound 4, half-maximal inhibitory concentration: > 100 ug/mL
Compound 4: only a limit was reported (the forecaster's own chance of this, stated with the estimate: 35%); middle value at least 2.5-fold (0.39 log units) away from the limit.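

In this assay compound 4 gives > 100 ug/mL, a limit of the assay and not a number, so a second compound now rests there: the limit of > 100 ug/mL in this assay, at which 2 of the 4 values shown sit. The imine of compound 4 does not repeat the gain seen with benzoyl, with an at least 10-fold higher number from compound 2 to compound 4 (1.00 log units; beyond the scatter), and it also falls behind the free amine, with an at least 4.0-fold higher number from compound 1 to compound 4 (0.60 log units; beyond the scatter). Of the groups shown at this position, therefore, only benzoyl lowers the number, and two different larger groups, one joined through a carbonyl and one through an imine, both end at the limit, though the step between compound 3 and compound 4 cannot be read: both results are limits.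

Going by these compounds, how far compound 3 and compound 4 lie beyond the limit stays open, as does which feature of these two larger groups separates them from benzoyl. The compounds shown also leave open how a small acetyl group on this nitrogen, a saturated 3-phenylpropanoyl chain in place of the 2-phenylethenyl carbonyl, or an imine whose phenyl ring lacks the dimethylamino group would read on this assay.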